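The compounds below may be only part of what the source reports. "The series", "measured", "known", "first", "only" and "open" are said of these compounds alone.

In a functional assay on U-251 cells (Homo sapiens) for inhibition, read by MTT assay, with a stated time of 2 days (a higher number here means a weaker inhibitor of growth, a lower number a stronger inhibitor of growth), compound 1 `Nc1ccccc1NC(=O)CCCNCC(=O)Nc1ccc(Cl)cc1` gives 11400 nM, compound 2 `Nc1ccccc1NC(=O)CCCNCC(=O)Nc1ccc(Br)cc1` gives 10400 nM and compound 3 `Nc1ccccc1NC(=O)c1ccc(NCC(=O)Nc2ccc([N+](=O)[O-])cc2)cc1` gives 8200 nM. Compound 3 therefore lies within the usual scatter of both other compounds, and the three cannot be ranked. Compound 4 `Nc1ccccc1NC(=O)c1ccc(NCC(=O)Nc2cccc([N+](=O)[O-])c2)cc1` has 3-nitrophenyl in place of 4-nitrophenyl on an amide-type nitrogen. Going by the values given here, no measured pair makes this exchange. Among the compounds with values here, the only measured single-place step is a 1.1-fold lower number from compound 1 to compound 2 (0.04 log units; within the scatter), which exchanges chloro for bromo and so offers only a loose guide. With nothing pointing to a larger shift, no change beyond the scatter is expected, and neither direction is favoured. The expected step is a 1.0-fold lower number from compound 3 to compound 4 (0.01 log units; within the scatter). Compound 4 is estimated at 8000 nM, with an expected range of 4000 nM to 16000 nM.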

Compound 4, concentration for 50% growth inhibition: 13500 nM
Compound 4: middle estimate off by 1.7-fold (0.23 log units), on the low side, within the range that was stated.
By their numbers in this assay, from the lowest: compounds 3, 2, 1 and 4 (each within the scatter of the next).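

In this assay, 3-nitrophenyl in place of 4-nitrophenyl on an amide-type nitrogen gives a 1.6-fold higher number from compound 3 to compound 4 (0.22 log units; within the scatter). The two compounds hold the same atoms, joined differently, so this step tests the place of the nitro group alone, and at this amide-type nitrogen that exchange cannot be told apart from repeat-measurement noise. No supporting data bear on this result. Still open, on these data alone, is whether an amine or a carboxylic acid in place of the nitro group would move the number beyond the scatter.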